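The source may report more compounds than this note shows. Statements on the series, on what has been measured and on what is new or still open speak of the compounds shown alone.

Measured so far in a physicochemical assay for lipophilicity, read by HPLC, measured as chromatographic lipophilicity, at pH 7.4 (a lower number here means a more polar compound, a higher number a more lipophilic compound), are these compounds:
- compound 1 `O=C(C1CCN(c2ncccn2)CC1)N1N=CC[C@H]1c1ccccc1` gives 4.7
- compound 2 `CC(C)(C)C(=O)n1nccc1-c1ccccc1` gives 8.3
- compound 3 `CC(C)(C)C(=O)N1CCSC1c1ccccc1` gives 5.6

Of these three, compound 1 stands lowest. Compound 3 lies nearest to it and compound 2 furthest from it, and both lie higher by more than the usual scatter.

The next compound to be read is compound 4 `O=C(c1cscn1)N1CCC(C(=O)N2N=CC[C@H]2c2ccccc2)CC1` and it departs from compound 1 in one place. A (1,3-thiazol-4-yl)carbonyl stands in place of pyrimidin-2-yl on an amine nitrogen in a ring ((1,3-thiazol-4-yl)carbonyl in place of pyrimidin-2-yl on an amine nitrogen in a ring) and the rest of the structure is unchanged. For the measured compounds named here, no pair of measured compounds differs in one place only, so the data give no direct measure of this exchange. The expectation therefore rests on the structural change alone and remains uncertain. In this assay a modest downward move is expected, probably just beyond the scatter, though a result within it would not surprise. The estimated a number 0.60 log units lower from compound 1 to compound 4 (beyond the scatter) would leave the new compound lowest of the four. For compound 4 the expected value is 4.1 with an estimated range from 3.4 to 4.8 at its upper end.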

Compound 4, distribution coefficient: 3
For compound 4 the middle estimate is 1.10 log units above the measured one; the measured number lies below the stated range.
By their numbers in this assay, from the lowest: compound 4; then compound 1; then compound 3; then compound 2.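

In this assay, the exchange of pyrimidin-2-yl for (1,3-thiazol-4-yl)carbonyl gives a number 1.70 log units lower from compound 1 to compound 4 (beyond the scatter), a large step and the first direct measure of any single change in this set. It shows that the group on this amine nitrogen in a ring, three ring bonds from the ring atom that bears a large group, can move the number well beyond the scatter while the rest of the structure stays unchanged. The exchange alters several counted features at once, replacing a six-membered aromatic ring with a five-membered one and adding sulfur, a double bond outside aromatic rings and a further hydrogen-bond acceptor, and nothing available here explains the size of the step.

The compounds shown leave open how much of the step belongs to the carbonyl and how much to the ring, a question that an acetyl group or a 1,3-thiazol-4-yl group bonded directly to the same nitrogen would address. They also leave open whether the same exchange would give a step of similar size on a different core.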